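Replacing fluoro with amino: the expected dose for compound 4

This account rests on a few compounds, and the source may have more. Where it says the series, first, only, none or still open, it means among the compounds named here.

compound 1 `O=C(Nc1ccncc1)Nc1ccccc1F`: 100 mg/kg
compound 2 `O=C(Nc1ccncc1)Nc1ccccc1C(F)(F)F`: 100 mg/kg
compound 3 `O=C(Nc1ccncc1)Nc1ccccc1OCc1ccccc1`: a limit, > 300 mg/kg

Of the compounds shown here, three have been measured in a functional assay on the whole organism with Mus musculus as the target, in the maximal electroshock model, with a stated time of 30 min; a lower number here means that less compound is needed, a higher number that more compound is needed for the effect. Compound 1 gives 100 mg/kg. Compound 2, with trifluoromethyl in place of fluoro on an aromatic carbon, gives 100 mg/kg, and the step reads no change at the digits printed from compound 1 to compound 2 (within the scatter); compound 1 therefore stands level with compound 2 on the numbers shown. For compound 3 the assay reports only a limit, > 300 mg/kg. Against compound 1 this step, benzyloxy in place of fluoro on an aromatic carbon, reads an at least 3.0-fold higher number from compound 1 to compound 3 (0.47 log units; beyond the scatter), and the same is seen from compound 2, an at least 3.0-fold higher number from compound 2 to compound 3 (0.47 log units; beyond the scatter). Among the measured compounds shown here, the one piece of evidence here is the limit of > 300 mg/kg in this assay, at which 1 of the 3 values shown sits, so the size of that step is known only as a lower bound.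

Compound 4 `Nc1ccccc1NC(=O)Nc1ccncc1` is not yet measured. Its difference from compound 1 is amino in place of fluoro on an aromatic carbon. Both measured steps alter the same aromatic carbon: one left the dose unchanged, the other raised it at least modestly. Neither involves amino, so the shared core is the only firm ground. The step to compound 4 is therefore expected to be no change at the digits printed from compound 1 to compound 4 (within the scatter), with the wider spread on the higher side. Compound 4 is estimated at 100 mg/kg, expected to lie between 50 mg/kg and 300 mg/kg.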

Compound 4, minimum effective dose: > 300 mg/kg
Compound 4: a limit, no number (the forecaster's own chance of this, stated with the estimate: 30%); at least 3.0-fold (0.47 log units) between middle value and limit.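

In this assay, a change at this aromatic carbon, ortho to a large group, now raises the number with a second group, and that group is amino, which enters with 1 heavy atom where fluoro leaves with 1 heavy atom: the step reads an at least 3.0-fold higher number from compound 1 to compound 4 (0.47 log units; beyond the scatter). The comparison with trifluoromethyl points the same way, with an at least 3.0-fold higher number from compound 2 to compound 4 (0.47 log units; beyond the scatter), so the rise no longer rests on benzyloxy alone, while fluoro and trifluoromethyl remain the two groups that stay level with each other. The step between amino and benzyloxy cannot be read, and how far either group raises the number stays unknown because both compounds rest on the same assay limit: the limit of > 300 mg/kg in this assay, at which 2 of the 4 values shown sit.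

The compounds shown leave open whether a hydroxyl or a methoxy group on this carbon would stay level with fluoro and trifluoromethyl or fall with amino and benzyloxy. They also leave open whether a methylamino or an acetamido group would behave as amino does here, or whether chloro would match fluoro on the same core.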